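Aromatase inhibition in a pyridinyloxy benzonitrile series

The compounds below may be only part of what the source reports. "The series", "measured", "known", "first", "only" and "open" are said of these compounds alone.

Measured so far:
compound 1 `N#Cc1ccc(Oc2cccnc2)cc1NCc1ccccc1`, 58%
compound 2 `N#Cc1ccc(Oc2cccnc2)cc1NC1CCCCC1`, 33%
compound 3 `N#Cc1ccc(Oc2cccnn2)cc1`, 1%

Three compounds have been run in an assay on isolated protein for inhibition of Aromatase (Homo sapiens), read by fluorescence, tested at 1 uM; a higher number here means more inhibition at the concentration tested (going by the name of the read-out), a lower number less inhibition. Compound 2 stands second of the three: compound 1 sits higher by a number 25 percentage points lower from compound 1 to compound 2 (beyond the scatter), and compound 3, which carries no substituent at the position in question and a different heteroaryloxy group, gives 1%, the lowest number of the set.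

The next compound, compound 4 `N#Cc1ccc(Oc2cccnc2)cc1Oc1cccnc1`, follows from compound 2 by (pyridin-3-yl)oxy in place of cyclohexylamino on an aromatic carbon. The change sits on an aromatic carbon of the shared core, ortho to a cyano group and meta to a (pyridin-3-yl)oxy group.

Among the measured compounds shown here, no measured step involves this exact exchange. For the measured compounds named here, the only step in the set, from benzyl to cyclohexyl on the nitrogen at that position, is a number 25 percentage points lower from compound 1 to compound 2 (beyond the scatter), and it shows only that an aromatic ring at this place was read higher than a saturated one. Compound 4 re-introduces an aromatic ring there, though linked through oxygen rather than nitrogen, so a modest rise in this assay is expected: a number 12 percentage points higher from compound 2 to compound 4 (beyond the scatter). For compound 4 the expected value is 45%, with a range from 15% to 75%.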

Compound 4, a percentage reported as inhibition, at one concentration (the size of the read-out at that concentration, not a potency): 81%
Compound 4: middle estimate off by 36 percentage points, on the low side; the measured number lies above the stated range.
By their numbers in this assay, from the lowest: compound 3; then compound 2; then compound 1; then compound 4.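

In this assay the step from the cyclohexylamino group to (pyridin-3-yl)oxy on this aromatic carbon, ortho to a cyano group, is large: a number 48 percentage points higher from compound 2 to compound 4 (beyond the scatter) and it shows that this position can carry a group linked through oxygen and lacking a hydrogen-bond donor. Among the two nitrogen-linked groups, compound 1 gives 58% and compound 4 gives 81% with its oxygen link, so a nitrogen at this place and its hydrogen-bond donor are not needed for a high number at the concentration tested. No measured information accounts for the step, in which the ring and the linking atom change together.

The compounds shown leave open how much of the step belongs to the linking atom and how much to the ring; a cyclohexyloxy group and a (pyridin-3-yl)amino group at the same carbon would separate the two. Also open, from the compounds shown here alone, is whether the ring nitrogen of the entering group matters, which a phenoxy group in its place would test.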